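This account rests on a few compounds, and the source may have more. Where it says the series, first, only, none or still open, it means among the compounds named here.

Going by the values given here, compound 1 `COc1cc(-c2nnc3n2NC(c2ccco2)C(C(=O)c2ccccc2C)S3)cc(OC)c1OC` gives the highest of the two numbers so far in a functional assay on PC-3 cells (Homo sapiens) for cytotoxicity, read by MTT assay, with a stated time of 48 h (a higher number here means a weaker inhibitor, a lower number a stronger inhibitor), at 88400 nM. Its nearest neighbour, compound 2 `COc1cc(-c2nnc3n2NC(c2ccco2)C(C(=O)c2ccc(Cl)cc2)S3)cc(OC)c1OC`, gives 67800 nM in this assay; the step of a 1.3-fold lower number from compound 1 to compound 2 (0.12 log units; within the scatter) exchanges one aromatic ring for another on the carbonyl carbon. Compound 3 `COc1cc(-c2nnc3n2NC(c2ccco2)C(C(=O)C2CC2)S3)cc(OC)c1OC` differs from compound 1 by cyclopropyl in place of 2-methylphenyl on a carbonyl carbon. Among the compounds with values here, no measured step exchanges an aromatic ring for a small non-aromatic ring at that carbonyl, so the only step available bears on it loosely. For compound 3 the step of a 1.1-fold lower number from compound 1 to compound 3 (0.04 log units; within the scatter) is expected to stay within the scatter. Compound 3 is therefore estimated at 80000 nM, with a range from 30000 nM to 200000 nM.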

Compound 3, half-maximal inhibitory concentration: 95200 nM
The estimate for compound 3 lay 1.2-fold (0.08 log units) below the measured number; measured number inside the range.
By their numbers in this assay, from the lowest: compounds 2, 1 and 3 (each within the scatter of the next).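

With a non-aromatic ring on the carbonyl carbon, in this assay the step of a 1.1-fold higher number from compound 1 to compound 3 (0.03 log units; within the scatter) and the step of a 1.4-fold higher number from compound 2 to compound 3 (0.15 log units; within the scatter) both stay within the scatter. Cyclopropyl, with 3 heavy atoms, therefore cannot be told apart from 2-methylphenyl, with 7, or from 4-chlorophenyl at this position. Nothing available explains this flat reading. As far as these compounds go, whether an amine or a carboxylic acid on this carbonyl carbon would give a step beyond the scatter remains open, as does the effect of changes elsewhere on the shared core.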